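This account rests on a few compounds, and the source may have more. Where it says the series, first, only, none or still open, it means among the compounds named here.

Compound 1 `CC(C)(C)c1conc1N1C(=O)CSC1c1cccc(C(=O)NCCCCc2ccccc2)c1` and compound 2 `O=C(NCCCCc1ccccc1)c1cccc(C2SCC(=O)N2c2cccc(F)c2)c1` share the same core and differ only in the aryl group on the amide-type nitrogen in the ring. In a functional assay on HOS-TE85 cells (Homo sapiens) for inhibition, read by CCK-8 assay, with a stated time of 72 h (a higher number here means a weaker inhibitor, a lower number a stronger inhibitor), compound 1 gives > 1000 nM, which is a limit of the assay rather than a number. Going by the values given here, compound 2 gives 32.4 nM in this assay, the only number among the three values shown. Compound 3 `Cc1ccnc(N2C(=O)CS[C@H]2c2cccc(C(=O)NCCCCn3cccn3)c2)c1` gives > 10000 nM in this assay, again a limit. Among the compounds with values here, the one measured step, an at least 30-fold lower number from compound 1 to compound 2 (1.48 log units; beyond the scatter), shows that the group on the amide-type nitrogen can move the value a long way. Compound 4 `COc1c(F)cccc1N1C(=O)CSC1c1cccc(C(=O)NCCCCc2ccccc2)c1` differs from compound 2 by methoxy in place of hydrogen on an aromatic carbon, that is, 3-fluorophenyl to 3-fluoro-2-methoxyphenyl. Within the data shown here, no measured step adds a methoxy group to this ring, so that step only shows that the ring matters, not how this addition acts. The expected change is therefore none beyond the scatter, a 1.2-fold higher number from compound 2 to compound 4 (0.09 log units; within the scatter). Compound 4 is estimated at 40 nM in this assay, between 10 nM and 160 nM.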

Compound 4, half-maximal inhibitory concentration: 26.2 nM
Beside the measured number, compound 4's estimate is 1.5-fold (0.18 log units) above it; the measured number falls inside the stated range.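

Adding methoxy to the ring gives a 1.2-fold lower number from compound 2 to compound 4 (0.09 log units; within the scatter) in this assay, so on this aromatic carbon, ortho to a fluoro group, 3-fluoro-2-methoxyphenyl serves as well as 3-fluorophenyl. Replacing the five-membered aromatic ring on the amide-type nitrogen with this substituted phenyl ring gives an at least 38-fold lower number from compound 1 to compound 4 (1.58 log units; beyond the scatter), so the large step seen earlier also holds with methoxy present. That step starts from a limit of the assay, not from a number: the limit of > 1000 nM in this assay, at which 1 of the 4 values shown sits.

Nothing shown here speaks to what lies behind the result for the methoxy group. On these data alone, whether an amine, a carboxylic acid or a longer alkoxy chain on this same carbon would also leave the value in place stays open, as does methoxy on a phenyl ring without the fluoro group.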